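Swapping Piperidine for Piperazine in a Weakly Cytotoxic Series

The source may hold more compounds than are shown below. What is called first, only, known or untested is meant among the compounds shown, and "the series" means these compounds.

Compound 1 `COc1ccc(Nc2cc(C)nc(SCc3nc4ccccc4[nH]3)n2)cc1` gives 67400 nM in a functional assay on PC-3 cells (Homo sapiens) for cytotoxicity, read by MTT assay, with a stated time of 72 h; on this read-out higher numbers stand for weaker inhibition and lower numbers for stronger inhibition. Compound 2 `Cc1cc(N2CCCCC2)nc(SCc2nc3ccccc3[nH]2)n1` reaches only a limit there, > 100000 nM; this is the limit of > 100000 nM in this assay, at which 1 of the 2 values shown sits. The step of an at least 1.4-fold higher number from compound 1 to compound 2 (0.17 log units; that floor lies within the scatter) thus has only a floor, and that floor lies within the scatter. Compound 3 `Cc1cc(N2CCNCC2)nc(SCc2nc3ccccc3[nH]2)n1` differs from compound 2 by piperazin-1-yl in place of piperidin-1-yl on an aromatic carbon. Among the compounds with values here, no measured step covers this change, and compound 2 already stands at the limit, so any movement in this assay is expected to stay within the scatter or to remain unreadable. The step of a number no higher from compound 2 to compound 3 (the limit leaves the size open) is therefore expected to be small. Compound 3 is estimated at 100000 nM, between 40000 nM and 300000 nM.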

Compound 3, half-maximal inhibitory concentration: > 100000 nM
Compound 3 gave a limit, no number; the forecaster's own chance of this, stated with the estimate: 60%; the middle value sits exactly at the limit.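

The change from piperidin-1-yl to piperazin-1-yl, which adds a hydrogen-bond donor at this position, gives a step that cannot be read, because compound 2 and compound 3 both stand at a limit and not at a number: the limit of > 100000 nM in this assay, at which 2 of the 3 values shown sit. The change from (4-methoxyphenyl)amino to piperazin-1-yl gives an at least 1.4-fold higher number from compound 1 to compound 3 (0.17 log units; that floor lies within the scatter). Neither ring at this position therefore yields a number in this assay, whereas compound 1 does.

From the compounds shown here alone, whether the two rings differ at all stays open. So does whether morpholin-4-yl or a benzylamino group at this position would give a measurable value.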